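A few compounds are considered here, and "the series" means these few. Any claim that something is new, unique, unknown or untested is made for them only; others in the source may bear on it.

In a functional assay on KB cells (Homo sapiens) for cytotoxicity, with a stated time of 72 h (a higher number here means that more compound is needed for the effect, a lower number that less compound is needed), compound 1 (`CO[C@@]12CC[C@H](O)[C@@](C)(CC[C@@H]3/C(=C\C=C\C(C)(C)O)COC(=O)[C@H]31)C2`) gives > 20 ug/mL, which is a limit of the assay and not a number. Compound 2 (`C=C1C(=O)[C@H](OC(=O)c2ccccc2)/C=C(\C)CC[C@@H]2C([C@H](OC(C)=O)[C@@H](C=C(C)C)OC(C)=O)=CO[C@@H](OC(C)=O)[C@@H]12`), a structurally different compound, gives > 20 ug/mL, also a limit. The picture so far is therefore (the limit of > 20 ug/mL in this assay, at which 2 of the 2 values shown sit), and compound 1 has no measured potency to serve as a starting point.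

Compound 3 (`CO[C@@]12CC[C@H](OC(C)=O)[C@@](C)(CC[C@@H]3/C(=C\C=C\C(C)(C)O)COC(=O)[C@H]31)C2`) keeps the core of compound 1 and changes it in one place: acetyl in place of hydrogen on an oxygen on a saturated carbon. In words, hydroxy becomes acetoxy, on an oxygen on a saturated carbon. For the measured compounds named here, no measured pair of compounds shows what this change does in this assay, so no shift beyond the usual scatter is expected in either direction, and compound 3 may well also reach only the limit. The expected step of a number no higher from compound 1 to compound 3 (the limit leaves the size open) reflects this. The estimated value for compound 3 is 20 ug/mL, with an expected range of 8 ug/mL to 40 ug/mL.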

Compound 3, concentration for half-maximal effect: > 20 ug/mL
Compound 3: no number, only a limit; the forecaster's own chance of this, stated with the estimate: 70%; the middle value lies on the limit itself.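

Compound 1 and compound 3 both give only a limit of the assay and not a number, so no step between them can be read: the limit of > 20 ug/mL in this assay, at which 3 of the 3 values shown sit.

The compounds shown leave open what acetoxy in place of hydroxy does to potency in this assay, and which structures would give a measured value there.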